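Swapping the N-Aryl Group of a Pyrrole Ketone Series

This account rests on a few compounds, and the source may have more. Where it says the series, first, only, none or still open, it means among the compounds named here.

Measured so far:
- Compound 1 `COc1cc(C(=O)c2cn(-c3ccccc3[N+](=O)[O-])cc2-c2ccccc2)cc(OC)c1OC`: 5000 nM
- Compound 2 `COc1cccc(-n2cc(C(=O)c3cc(OC)c(OC)c(OC)c3)c(-c3ccccc3)c2)c1`: 500 nM
- Compound 3 `COc1ccc(-n2cc(C(=O)c3cc(OC)c(OC)c(OC)c3)c(-c3ccccc3)c2)cc1`: 120 nM

All three were tested in a functional assay on MCF7 cells (Homo sapiens) for cytotoxicity, read by MTT assay, with a stated time of 96 h; a lower number here means a stronger inhibitor, a higher number a weaker inhibitor. Compound 1 gives the highest number of the three, which here means the weakest cytotoxic effect: the step of a 10-fold lower number from compound 1 to compound 2 (1.00 log units; beyond the scatter) and the larger step of a 42-fold lower number from compound 1 to compound 3 (1.62 log units; beyond the scatter) both leave compound 1 behind, and a 4.2-fold lower number from compound 2 to compound 3 (0.62 log units; beyond the scatter) separates the two methoxyphenyl compounds.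

Compound 4 `COc1cc(C(=O)c2cn(-c3cc(OC)c(OC)c(OC)c3)cc2-c2ccccc2)cc(OC)c1OC` has not been measured. Compared with compound 1 it differs in one place: 3,4,5-trimethoxyphenyl in place of 2-nitrophenyl on an aromatic nitrogen

The two measured steps that bear on this change are those from compound 1, a 10-fold lower number from compound 1 to compound 2 (1.00 log units; beyond the scatter) and a 42-fold lower number from compound 1 to compound 3 (1.62 log units; beyond the scatter), each replacing the 2-nitrophenyl with a methoxyphenyl and each lowering the number well beyond the scatter. Going by the values given here, the entering 3,4,5-trimethoxyphenyl is another methoxy-bearing aryl, so a step of similar kind is expected, though no measured pair shows this exact group. For compound 4 the expected step is a 28-fold lower number from compound 1 to compound 4 (1.44 log units; beyond the scatter), giving an estimate of 180 nM with a range from 45 nM to 720 nM.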

Compound 4, half-maximal inhibitory concentration: > 5000 nM
Compound 4: a limit, no number (the forecaster's own chance of this, stated with the estimate: 2%); middle value at least 27-fold (1.44 log units) away from the limit.
By their numbers in this assay, from the lowest: compound 3; then compound 2; then compound 1.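

In this assay compound 4 gives > 5000 nM, which is a limit of the assay and not a number. Adding methoxy groups to the aryl on the aromatic nitrogen does not preserve the activity seen with a single methoxy: the change to 3,4,5-trimethoxyphenyl brings an at least 41-fold higher number from compound 3 to compound 4 (1.61 log units; beyond the scatter) and an at least 10-fold higher number from compound 2 to compound 4 (1.00 log units; beyond the scatter). So at this position, the presence of methoxy on the aryl ring is not enough on its own, while the change from 2-nitrophenyl to 3,4,5-trimethoxyphenyl brings a number no lower from compound 1 to compound 4 (the limit leaves the size open).

The compounds shown leave open how far beyond the limit compound 4 really lies and how many methoxy groups this position tolerates. A 3,4-dimethoxyphenyl would test the second question, and a 4-aminophenyl, with an amine in place of the methoxy, would show whether methoxy itself is needed.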